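The compounds below may be only part of what the source reports. "The series", "measured", "known", "first", "only" and "open" are said of these compounds alone.

Of the compounds shown here, three have numbers so far. In an ADME assay on L6 cells (Rattus norvegicus) for cytotoxicity (on this read-out lower numbers stand for stronger inhibition and higher numbers for weaker inhibition), compound 1 (`CN1CCN(CC(=O)NC2CC3(N4CCN(C)CC4)CC(c4ccccc4)C2C(c2ccccc2)C3)CC1`) reads 42100 nM and compound 2 (`CN1CCN(CCN2CCC3(N4CCCC4)CC(c4ccccc4)C2C(c2ccccc2)C3)CC1`) reads 50300 nM, while compound 3 (`CN1CCN(CCCC(=O)OC2CC3(N4CCCCC4)CC(c4ccccc4)C2C(c2ccccc2)C3)CC1`) reads 22300 nM on the same scale. Compound 3 lies within the scatter of compound 1, so no order is drawn between those two. Its number is lower than that of compound 2, by a margin just beyond the scatter.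

The step to follow is from compound 3 to compound 4 (`O=C(CN1CCCCC1)OC1CC2(N3CCCCC3)CC(c3ccccc3)C1C(c1ccccc1)C2`). The shared core stays and the change falls in one place, on a saturated chain carbon bound to a carbonyl carbon (piperidin-1-yl in place of 2-(4-methylpiperazin-1-yl)ethyl on a saturated chain carbon bound to a carbonyl carbon). Cut one bond further out, the same difference reads 3-(4-methylpiperazin-1-yl)propyl to (piperidin-1-yl)methyl.

Among the measured compounds shown here, no pair of measured compounds differs in one place only, so the series offers no direct precedent for this change. For the measured compounds named here, the only guide is the narrow spread of the three numbers, from compound 3 at 22300 nM to compound 2 at 50300 nM on the same read-out. The expected change (a 1.2-fold higher number from compound 3 to compound 4 (0.08 log units; within the scatter)) is estimated to stay within the scatter, with no firm direction. In this assay the estimated value for compound 4 is 27000 nM with an expected range of 11000 nM to 65000 nM for this measurement.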

Compound 4, half-maximal inhibitory concentration: 60400 nM
For compound 4 the middle estimate is 2.2-fold (0.35 log units) below the measured one; the range from low to high includes it.
By their numbers in this assay, from the lowest: compounds 3, 1, 2 and 4 (each within the scatter of the next, the first and the last beyond it).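

The series now has its first one-place step: on a saturated chain carbon bound to a carbonyl carbon, piperidin-1-yl in place of 2-(4-methylpiperazin-1-yl)ethyl gives, in this assay, a 2.7-fold higher number from compound 3 to compound 4 (0.43 log units; beyond the scatter), a modest move towards weaker inhibition. This position therefore responds to substitution on this read-out, although a single step shows this only for one pair. The change alters two things at once, since cut one bond further out it reads 3-(4-methylpiperazin-1-yl)propyl to (piperidin-1-yl)methyl, and nothing available explains the shift.

Still open, as far as these compounds go, is whether the shift follows the shorter chain or the exchange of the ring: a 4-methylpiperazin-1-yl group on the same carbon, or a 2-(piperidin-1-yl)ethyl group, would separate the two. Also open, from the compounds shown here alone, is whether the step carries over to other groups at this position, such as a morpholin-4-yl ring or an open-chain dimethylamino group.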